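A few compounds are considered here, and "the series" means these few. Any claim that something is new, unique, unknown or untested is made for them only; others in the source may bear on it.

Of the compounds shown here, three built on one shared core have been measured in a functional assay on NUGC-3 cells (Homo sapiens) for cytotoxicity, read by sulforhodamine B assay, with a stated time of 72 h; on this read-out higher numbers stand for weaker inhibition of growth and lower numbers for stronger inhibition of growth. Compound 1, `O=C(Nc1ccc(C(F)(F)F)cc1)C1CCc2ccccc2N1`, gives 18600 nM. Compound 2, `CCC(=O)N1c2ccccc2CCC1C(=O)Nc1ccccc1C(F)(F)F`, reaches only a limit of the measurement in this assay, reported as > 80000 nM. Compound 3, `O=C(Nc1ccc(O)cc1)C1CCc2ccccc2N1`, likewise gives only a limit in this assay, reported as > 100000 nM. As far as these compounds go, compound 3 therefore stands at the weak end of what has been seen: the change from compound 1 to compound 3, hydroxy in place of trifluoromethyl on an aromatic carbon, gave an at least 5.3-fold higher number from compound 1 to compound 3 (0.73 log units; beyond the scatter), and because compound 3 sits at the limit of > 100000 nM in this assay, at which 1 of the 3 values shown sits, its true number remains unknown.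

Compound 4, `COc1ccc(NC(=O)C2CCc3ccccc3N2)cc1`, is one step away from compound 3: methyl in place of hydrogen on an oxygen on an aromatic ring. Among the compounds with values here, no measured pair shows this change, methyl in place of hydrogen on an oxygen on an aromatic ring, so its size cannot be read from the present data; the single measured step, from compound 1 to compound 3, concerns a different group and ends at a limit. The step is therefore expected to be an at least 1.4-fold lower number from compound 3 to compound 4 (0.15 log units; that floor lies within the scatter), small or none beyond the scatter, with the open possibility of somewhat stronger growth inhibition. Compound 4 is thus expected to give about 70000 nM in this assay, within a range from 20000 nM to 200000 nM, and may again come back only as a limit.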

Compound 4, concentration for 50% growth inhibition: 51900 nM
Beside the measured number, compound 4's estimate is 1.3-fold (0.13 log units) above it; measured number inside the range.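

Placing a methyl on the oxygen on the aromatic ring turns a result that was only a limit into a readable number: in this assay, the change gives an at least 1.9-fold lower number from compound 3 to compound 4 (0.28 log units; that floor lies within the scatter), the first measured case of this change in the series. Within the data shown here, the true size of this step stays unknown, and its floor alone does not go beyond the usual scatter, because one end of the step is not a number: the limit of > 100000 nM in this assay, at which 1 of the 4 values shown sits. The step that compares methoxy directly with trifluoromethyl, a 2.8-fold higher number from compound 1 to compound 4 (0.45 log units; beyond the scatter), is the first one on that aromatic carbon with a real number at both ends, so the order of these two groups can be read, and trifluoromethyl gives the lower number.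

Still open, as far as these compounds go, is whether a longer chain on the same oxygen, such as ethoxy or propoxy, would keep, lower or raise the number seen with methoxy. It is also unknown how an amine or a carboxylic acid in place of trifluoromethyl on that aromatic carbon would compare with the two groups that now have real numbers.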